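A few compounds are considered here, and "the series" means these few. Any claim that something is new, unique, unknown or untested is made for them only; others in the source may bear on it.

Of the compounds shown here, two built on one shared core have been measured in a functional assay on HT-29 cells (Homo sapiens) for antiproliferative activity, read by sulforhodamine B assay, with a stated time of 72 h; a lower number here means a stronger inhibitor, a higher number a weaker inhibitor. Compound 1 `Fc1ccccc1NC(=S)N/N=C/c1ccc2ccccc2n1` carries a 2-fluorophenyl group on an amide-type nitrogen. In this assay compound 1 reaches only a limit of the assay, > 100000 nM. Compound 2 `S=C(NCc1ccccc1)N/N=C/c1ccc2ccccc2n1` carries a benzyl group in that place instead, and in this assay compound 2 gives 75700 nM. For the measured compounds named here, the single measured step, an at least 1.3-fold lower number from compound 1 to compound 2 (0.12 log units; that floor lies within the scatter), has a floor that lies within the usual scatter, so compound 2 stands as the one compound with a real number rather than a limit. Compound 3 `S=C(N/N=C/c1ccc2ccccc2n1)Nc1ccc(Cl)cc1` differs from compound 2 in one place: 4-chlorophenyl in place of benzyl on an amide-type nitrogen. Going by the values given here, this change brings an aromatic ring back onto that nitrogen, the reverse sense of the only measured step, and the value of compound 1 sits at the limit of > 100000 nM in this assay, at which 1 of the 2 values shown sits. The estimated step of a 1.3-fold higher number from compound 2 to compound 3 (0.12 log units; within the scatter) is therefore expected to be small, toward a weaker inhibitor or none beyond the scatter. Compound 3 is estimated at 100000 nM, with a range from 30000 nM to 300000 nM.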

Compound 3, half-maximal inhibitory concentration: 97200 nM
The estimate for compound 3 lay 1.0-fold (0.01 log units) above the measured number; the measured number falls inside the stated range.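

For the compounds shown here, with compound 3, a second real number stands on this position, so a swap on the nitrogen bonded to the thiocarbonyl carbon can be read as a full step for the first time rather than as a floor. In this assay, putting 4-chlorophenyl in place of benzyl gives a 1.3-fold higher number from compound 2 to compound 3 (0.11 log units; within the scatter), so this exchange of one aromatic group for another shows no change that can be told apart from repeat measurements. Replacing 2-fluorophenyl with 4-chlorophenyl gives an at least 1.0-fold lower number from compound 1 to compound 3 (0.01 log units; that floor lies within the scatter), and that floor settles nothing, since the value of compound 1 is a limit of the assay and not a number: the limit of > 100000 nM in this assay, at which 1 of the 3 values shown sits.

The groups shown on this nitrogen all carry a six-membered aromatic ring of carbon, so whether a group without such a ring, such as a simple methyl, an aminoethyl chain or a chain ending in a carboxylic acid, would move the number beyond the scatter remains open. Also open, going by these compounds, is how a change elsewhere on the shared core would compare with these swaps.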